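From pyridin-2-yl to benzyl on the shared core

The compounds below may be only part of what the source reports. "The series", "measured", "known", "first", "only" and "open" are said of these compounds alone.

Compound 1 `CCCCCCCCc1ccc(OCC(=O)Cn2nnc(-c3ccncc3)n2)cc1`: < 5% (a limit)
Compound 2 `CCCCCCCCc1ccc(OCC(=O)Cn2nnc(-c3ccccn3)n2)cc1`: 30%

Both compounds were tested in an ADME assay on S9 fraction from liver (Rattus norvegicus) for metabolic stability, read by LC-MS, using NADPH, with a stated time of 30 min; on this read-out lower numbers stand for a less stable compound and higher numbers for a more stable compound. Compound 1 reads < 5%, which is a limit of the assay and not a number. Among the measured compounds shown here, compound 2 gives 30%, the only actual number in this small set.

The next compound is compound 3 `CCCCCCCCc1ccc(OCC(=O)Cn2nnc(Cc3ccccc3)n2)cc1`, which carries benzyl in place of pyridin-2-yl on an aromatic carbon.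

For the measured compounds named here, only one measured step bears on this change. It shows a number at least 25 percentage points higher from compound 1 to compound 2 (beyond the scatter), with pyridin-2-yl in place of pyridin-4-yl on an aromatic carbon. Going by the values given here, that step shows that a change at this place can move the read-out in this assay, but it exchanges one pyridinyl group for another, and no benzyl compound has a measured value. It therefore gives no firm direction for the new change, so only a small fall, within the scatter, is expected. The expected change is a number 8 percentage points lower from compound 2 to compound 3 (within the scatter). Compound 3 is estimated at 22%, with an expected range from 6% to 45%.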

Compound 3, percent of the compound remaining: < 5%
Compound 3 gave a limit, no number (the forecaster's own chance of this, stated with the estimate: 15%); at least 17 percentage points between middle value and limit.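

Placing benzyl instead of pyridin-2-yl on this aromatic carbon gives a number at least 25 percentage points lower from compound 2 to compound 3 (beyond the scatter) in this assay, so the higher reading of compound 2 now stands apart from both other groups shown at this place. A ring nitrogen alone does not go with a higher reading, as pyridin-4-yl also carries one and compound 1 stays at a limit, not a number; among the three compounds, only pyridin-2-yl gives a number. The step between compound 1 and compound 3 cannot be read: the limit of < 5% in this assay, at which 2 of the 3 values shown sit.

Benzyl differs from pyridin-2-yl both in its ring of carbon only and in the extra carbon that links this ring to the core, so the compounds shown do not separate these two differences, and it remains open how phenyl or pyridin-2-ylmethyl at this place would read. Also open, on these data alone, is how an amine or a carboxylic acid on this aromatic carbon would read in this assay.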